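Pyridyl amide positional isomers on a shared core

The source may report more compounds than this note shows. Statements on the series, on what has been measured and on what is new or still open speak of the compounds shown alone.

Compound 3 `COc1ccc(-c2cccc(C(=O)N(C)Cc3ccccn3)c2)cc1S(=O)(=O)Nc1cccc(NCCNC(=O)c2cccc(C)c2)c1` gives 96% in a functional assay on CHO-RD-HGA16 cells for agonist activity at Orexin/Hypocretin receptor type 1 (Homo sapiens), read by fluorescence and calcium flux, with a stated time of 30 min; on this read-out lower numbers stand for smaller maximal responses and higher numbers for larger maximal responses. In this assay compound 1 `COc1ccc(-c2cccc(C(=O)N(C)C)n2)cc1S(=O)(=O)Nc1cccc(NCCNC(=O)c2cccc(C)c2)c1` gives 100%, and compound 2 `COc1ccc(-c2cccc(C(=O)N(C)CCN(C)C)c2)cc1S(=O)(=O)Nc1cccc(NCCNC(=O)c2cccc(C)c2)c1` gives 102%; the three values lie within the usual scatter of one another. Among the measured compounds shown here, the only single-change step among them, a number 6 percentage points lower from compound 2 to compound 3 (within the scatter), also stays within the scatter. Compound 4 `COc1ccc(-c2cccc(C(=O)N(C)Cc3cccnc3)c2)cc1S(=O)(=O)Nc1cccc(NCCNC(=O)c2cccc(C)c2)c1` differs from compound 3 by pyridin-3-yl in place of pyridin-2-yl on a saturated chain carbon bound to an amide-type nitrogen. For the measured compounds named here, no measured pair covers this exchange, so no direct precedent exists. Because a number 6 percentage points lower from compound 2 to compound 3 (within the scatter) stays within the scatter, and the values of compounds 1, 2 and 3 lie within the scatter of one another, the expected step of a number 1 percentage points higher from compound 3 to compound 4 (within the scatter) is none beyond the scatter. Compound 4 is estimated at 97%, with a range from 85% to 109%.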

Compound 4, largest response reached (Emax), in percent of the reference or control that the assay uses: 98%
The estimate for compound 4 lay 1 percentage points below the measured number, and the stated range covers the measured number.
By their numbers in this assay, from the lowest: compounds 3, 4, 1 and 2 (each within the scatter of the next).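

Pyridin-3-yl in place of pyridin-2-yl on a saturated chain carbon bound to an amide-type nitrogen gives a number 2 percentage points higher from compound 3 to compound 4 (within the scatter) in this assay, the first reading on this isomer exchange. Pyridin-3-yl in place of (dimethylamino)methyl at the same place gives a number 4 percentage points lower from compound 2 to compound 4 (within the scatter), so neither pyridyl isomer separates from the (dimethylamino)methyl group at this position. No evidence bearing on a reason for this is available.

The compounds shown leave open how pyridin-4-yl, a carboxylic acid or a longer chain would behave at this place. Potency also stays open, as only largest responses are shown.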